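The source may report more compounds than this note shows. Statements on the series, on what has been measured and on what is new or still open speak of the compounds shown alone.

Measured so far: compound 1, `Cn1cc(/C=C2/C(=O)Nc3ccccc32)c2cc(Nc3nccc(-c4ccc(Cl)cc4)n3)ccc21`, gives 2430 nM in a functional assay on PA-1 cells (Homo sapiens) for cytotoxicity, read by MTT assay, with a stated time of 48 h; on this read-out higher numbers stand for weaker inhibition and lower numbers for stronger inhibition; compound 2, `Cn1cc(/C=C2/C(=O)Nc3ccccc32)c2cc(Nc3nccc(-c4ccc(F)cc4)n3)ccc21`, gives 31800 nM in this assay.

Going by the values given here, compound 2 thus stands at the highest of the two numbers, meaning the weaker inhibition of the pair; its only neighbour is compound 1, and the single measured step between them is a 13-fold higher number from compound 1 to compound 2 (1.12 log units; beyond the scatter), which is fluoro in place of chloro on an aromatic carbon.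

Compound 3, `Cn1cc(/C=C2/C(=O)Nc3ccccc32)c2cc(Nc3nccc(-c4ccc(Cl)cc4Cl)n3)ccc21`, is not yet measured. It differs from compound 2 in one place: 2,4-dichlorophenyl in place of 4-fluorophenyl on an aromatic carbon. Among the compounds with values here, the only step that bears on this change is the one from compound 1 to compound 2, where a large rise in the number accompanied the swap to fluoro. Going back to chloro should roughly undo that rise; what the second chloro adds is untested here, so the range is kept wide. Compound 3 is therefore expected to give about 2500 nM in this assay, between 600 nM and 10000 nM, an expected step of a 13-fold lower number from compound 2 to compound 3 (1.10 log units; beyond the scatter) toward stronger inhibition.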

Compound 3, half-maximal inhibitory concentration: > 100000 nM
Compound 3 was reported as a limit; the forecaster's own chance of this, stated with the estimate: 3%; at least 40-fold (1.60 log units) between middle value and limit.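

In this assay, compound 3 is reported only as a limit, not as an exact number: the limit of > 100000 nM in this assay, at which 1 of the 3 values shown sits. Even so, the added chlorine matters: chloro in place of hydrogen on an aromatic carbon of the phenyl group gives an at least 41-fold higher number from compound 1 to compound 3 (1.61 log units; beyond the scatter), so a single extra chlorine on this group separates a measurable number from the limit. The change from 4-fluorophenyl to 2,4-dichlorophenyl gives an at least 3.1-fold higher number from compound 2 to compound 3 (0.49 log units; beyond the scatter), so chlorine on this phenyl group does not by itself go with stronger inhibition, as compound 1 alone had suggested.

As far as these compounds go, whether a methyl or a methoxy group in place of that second chlorine would bring the same rise remains open. From the compounds shown here alone, how a phenyl group carrying no halogen would compare with these three compounds also remains open.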